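Swapping the side chain of compound 2

The source may hold more compounds than are shown below. What is called first, only, known or untested is meant among the compounds shown, and "the series" means these compounds.

Measured in a functional assay on MCF7 cells (Homo sapiens) for cytotoxicity, read by MTT assay, with a stated time of 72 h; a lower number here means a stronger inhibitor, a higher number a weaker inhibitor:
Compound 1 `O=C1c2c[n+]([O-])c3ccccc3c2C(=O)c2c1c1ccccc1n2Cc1cn([C@@H]2C[C@H](O)[C@@H](CO)O2)nn1` gives 110 nM
Compound 2 `O=C1c2c[n+]([O-])c3ccccc3c2C(=O)c2c1c1ccccc1n2CCN1CCCC1` gives 320 nM
Compound 3 `O=C1c2c[n+]([O-])c3ccccc3c2C(=O)c2c1c1ccccc1n2Cc1cn([C@H]2C[C@H](O)[C@@H](CO)O2)nn1` gives 530 nM

Compound 2 holds the second highest of the three numbers. Its value lies within the usual scatter of compound 3 and is clearly higher than that of compound 1. Compound 4 `CN1CCN(CCCCCCn2c3c(c4ccccc42)C(=O)c2c[n+]([O-])c4ccccc4c2C3=O)CC1` carries 4-(4-methylpiperazin-1-yl)butyl in place of pyrrolidin-1-yl, on a saturated chain carbon, two bonds along the chain from an aromatic nitrogen: 4-(4-methylpiperazin-1-yl)butyl in place of pyrrolidin-1-yl on a saturated chain carbon, two bonds along the chain from an aromatic nitrogen. Within the data shown here, the only measured step, a 4.8-fold higher number from compound 1 to compound 3 (0.68 log units; beyond the scatter), is a change of configuration alone (the fact that compounds 1 and 3 differ only in the configuration as drawn), so it bears on this swap only loosely. It does show that the number can move modestly within this series. No clear direction can be drawn from it, so a small change is expected in this assay. The expected step is a 1.3-fold higher number from compound 2 to compound 4 (0.10 log units; within the scatter). For compound 4 the estimated value is 400 nM, with an expected range from 130 nM to 1200 nM.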

Compound 4, half-maximal inhibitory concentration: 400 nM
Beside the measured number, compound 4's estimate shows no gap at the digits printed, within the range that was stated.
By their numbers in this assay, from the lowest: compound 1; then compounds 2, 4 and 3 (each within the scatter of the next).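

In this assay the step of a 1.3-fold higher number from compound 2 to compound 4 (0.10 log units; within the scatter) shows that the two numbers cannot be told apart, even though pyrrolidin-1-yl gives way to the larger 4-(4-methylpiperazin-1-yl)butyl at this position. Among these compounds, the earlier step changed only configuration, so this is the first reading of a change in the side chain itself. No available fact explains this result.
On these data alone, whether a carboxylic acid or a plain alkyl chain without an amine would give a similar number at this position remains open. So does the separate contribution of the butyl chain and the piperazine ring.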